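The compounds below may be only part of what the source reports. "The series", "measured", "known", "first", "only" and "open" are said of these compounds alone.

Measured compounds:
compound 1, `Oc1ccc(-c2cc(-c3ccccc3F)cc(-c3cccc(O)c3)n2)cc1`: 14300 nM
compound 2, `Oc1ccc(-c2cc(-c3ccccc3F)cc(-c3ccc(O)cc3)n2)cc1`: > 50000 nM
compound 3, `Oc1cccc(-c2cc(-c3ccccc3OC(F)(F)F)cc(-c3ccccc3O)n2)c1`: 15200 nM

In a functional assay on HeLa cells (Homo sapiens) for inhibition (a higher number here means a weaker inhibitor, a lower number a stronger inhibitor), compound 1 gives 14300 nM. For compound 2 the value is a limit of this assay, namely (the limit of > 50000 nM in this assay, at which 1 of the 3 values shown sits), so compound 2 gives > 50000 nM. The change between them is 4-hydroxyphenyl in place of 3-hydroxyphenyl on an aromatic carbon, and it produced an at least 3.4-fold higher number from compound 1 to compound 2 (0.54 log units; beyond the scatter). Compound 3 gives 15200 nM in this assay, a number that sits within the scatter of the number of compound 1; how the core of compound 3 differs from that of compound 1 is not broken down here.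

Compound 4, `Oc1ccc(-c2cc(-c3ccccc3OC(F)(F)F)cc(-c3ccccc3O)n2)cc1`, has not been measured. It differs from compound 3 by 4-hydroxyphenyl in place of 3-hydroxyphenyl on an aromatic carbon. This is the same kind of change as that from compound 1 to compound 2, though the surroundings differ: in compound 3 the place is meta to a 2-hydroxyphenyl group and meta to a large group, whereas in compound 1 it was meta to a 2-fluorophenyl group and meta to a 4-hydroxyphenyl group. Resting on an at least 3.4-fold higher number from compound 1 to compound 2 (0.54 log units; beyond the scatter), a step of similar direction, a 3.6-fold higher number from compound 3 to compound 4 (0.56 log units; beyond the scatter), is expected from compound 3 to compound 4. Compound 4 is therefore estimated at 55000 nM in this assay. The expected range for compound 4 runs from 25000 nM to 150000 nM.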

Compound 4, half-maximal inhibitory concentration: 6010 nM
The estimate for compound 4 lay 9.2-fold (0.96 log units) above the measured number, and the stated range ends above it.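

In this assay, placing 4-hydroxyphenyl instead of 3-hydroxyphenyl next to the ring nitrogen gave a 2.5-fold lower number from compound 3 to compound 4 (0.40 log units; beyond the scatter). Set beside the earlier step, this change did not carry over from one core to the other, and its direction reversed: the same change on two cores in this assay, an at least 3.4-fold higher number (0.54 log units; beyond the scatter) from compound 1 to compound 2 and a 2.5-fold lower number (0.40 log units; beyond the scatter) from compound 3 to compound 4, at least 8.8-fold (0.94 log units) apart, beyond the scatter of two such steps This shows that the outcome of the change depends on the rest of the molecule in these two pairs, but it does not show which of the differences between the two cores sets the outcome, and two pairs, one resting on a limit of the assay for compound 2, give no rule for a further core.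

The compounds shown leave open whether the 2-hydroxyphenyl group, the other aryl group or both decide the direction of the step. Also open, as far as these compounds go, is how an amine or a carboxylic acid in place of the hydroxy group on the 4-hydroxyphenyl ring would read in this assay.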